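A few compounds are considered here, and "the series" means these few. Any claim that something is new, unique, unknown or untested is made for them only; others in the source may bear on it.

Compound 1, `CNC(=O)/C=C1/COc2cc(OS(=O)(=O)c3ccccc3)ccc21`, gives 34 nM in an assay (strain Sprague-Dawley) for inhibition of Amine oxidase [flavin-containing] A (Rattus norvegicus), read by spectrophotometry, with a stated time of 5 min; on this read-out higher numbers stand for weaker inhibition and lower numbers for stronger inhibition.
Compound 2, `CNC(=O)/C=C1/COc2cc(OS(=O)(=O)c3ccc([N+](=O)[O-])cc3)ccc21`, gives 37 nM in this assay.

Compound 2 and compound 1 lie within the usual scatter of each other: the change a 1.1-fold higher number from compound 1 to compound 2 (0.04 log units; within the scatter) is too small to count as a real difference. Compound 3, `CNC(=O)/C=C1/COc2cc(OS(=O)(=O)c3ccc(S(C)(=O)=O)cc3)ccc21`, is not yet measured. It differs from compound 2 by methylsulfonyl in place of nitro on an aromatic carbon. Among the measured compounds shown here, the only step measured so far that touches this part of the molecule is the one from hydrogen to nitro, a 1.1-fold higher number from compound 1 to compound 2 (0.04 log units; within the scatter), which did not move the number beyond the scatter. For the measured compounds named here, no step from nitro to methylsulfonyl has been measured, so the expectation rests on that single neighbouring step. Compound 3 is therefore expected to show no step beyond the scatter, a 1.1-fold higher number from compound 2 to compound 3 (0.03 log units; within the scatter). The estimate for compound 3 in this assay is 40 nM, with a range from 15 nM to 110 nM.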

Compound 3, half-maximal inhibitory concentration: 19 nM
Compound 3: the middle estimate sits 2.1-fold (0.32 log units) above what was measured, within the range that was stated.
By their numbers in this assay, from the lowest: compounds 3, 1 and 2 (each within the scatter of the next).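

In this assay, putting methylsulfonyl in place of nitro gives a 1.9-fold lower number from compound 2 to compound 3 (0.29 log units; within the scatter), and putting it in place of hydrogen gives a 1.8-fold lower number from compound 1 to compound 3 (0.25 log units; within the scatter). The earlier pair showed only that nitro and hydrogen could not be told apart on this aromatic ring; now a third group at the same place, para to a large group, also falls within the scatter of both, so this position has accepted all three groups tried here without a real difference in the number. Nothing measured here offers an explanation for this result.

As far as these compounds go, whether an amine, a carboxylic acid or a longer chain at this place would also stay within the scatter remains open. So does the effect of any of these groups elsewhere on this ring.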